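The compounds below may be only part of what the source reports. "The series", "measured", "known", "first", "only" and "open" are said of these compounds alone.

Among the measured compounds shown here, in a physicochemical assay for solubility, in phosphate buffer, measured as kinetic solubility, at pH 7.4 (on this read-out higher numbers stand for higher solubility and lower numbers for lower solubility), compound 3 `CCc1ccccc1-c1nc(CN2CCC(C(=O)NCCCN3C[C@H](C)C[C@H](C)C3)CC2)c(C)o1` gives 55.9 ug/mL, and it is the only compound of the three measured so far to return an actual number. Compound 1 `Cc1oc(-c2ccc(Cl)cc2)nc1CN1CCC(C(=O)NCCCN2C[C@H](C)C[C@H](C)C2)CC1` reads > 72 ug/mL, which is a limit. Compound 2 `COc1cccc(Br)c1-c1nc(CN2CCC(C(=O)NCCCN3C[C@H](C)C[C@H](C)C3)CC2)c(C)o1` reads > 83 ug/mL, which is also a limit.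

The next compound, compound 4 `COc1cccc(C)c1-c1nc(CN2CCC(C(=O)NCCCN3C[C@H](C)C[C@H](C)C3)CC2)c(C)o1`, is not yet measured. In it, 2-methoxy-6-methylphenyl takes the place of 2-ethylphenyl on an aromatic carbon (2-methoxy-6-methylphenyl in place of 2-ethylphenyl on an aromatic carbon). For the measured compounds named here, three measured steps bear on this change. The first is an at least 1.4-fold lower number from compound 2 to compound 3 (0.17 log units; that floor lies within the scatter). The second is an at least 1.2-fold lower number from compound 1 to compound 3 (0.10 log units; that floor lies within the scatter). The third is a step that the two limits leave unreadable from compound 1 to compound 2. From the compounds shown here alone, the first two give only floors, so the true size of each remains open.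

The entering group shares its methoxy with 2-bromo-6-methoxyphenyl, and an at least 1.4-fold lower number from compound 2 to compound 3 (0.17 log units; that floor lies within the scatter) leads away from that group, so a small rise is expected in this assay. The expected change is a 1.3-fold higher number from compound 3 to compound 4 (0.10 log units; within the scatter), which is not expected to go beyond the scatter. For compound 4 the estimated value is 70 ug/mL, with an expected range from 38 ug/mL to 105 ug/mL.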

Compound 4, solubility: > 73 ug/mL
Compound 4: no number, only a limit (the forecaster's own chance of this, stated with the estimate: 40%); middle value at least 1.0-fold (0.01 log units) away from the limit.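

In this assay compound 4 gives a limit and not a number: the limit of > 73 ug/mL in this assay, at which 1 of the 4 values shown sits.

At this position, on an aromatic carbon next to the ring nitrogen and next to the ring oxygen, 2-methoxy-6-methylphenyl in place of 2-ethylphenyl gives an at least 1.3-fold higher number from compound 3 to compound 4 (0.11 log units; that floor lies within the scatter), a floor and not a size, so this direct change can only be said to stay within what the floor allows. Compound 2 and compound 4 share a methoxy and both end in limits, but compound 1, with 4-chlorophenyl and no methoxy, also ends in a limit, so the methoxy is not singled out, and the steps from compound 1 and from compound 2 to compound 4 cannot be read, since both ends of each are limits.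

The compounds shown leave open how far the true values of compound 1, compound 2 and compound 4 lie past their limits, and with that whether methyl in place of bromo changes anything in this assay. They also leave open what a phenyl carrying a methoxy alone, without a methyl or bromo, or one carrying a nitrile, would return at this position.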